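A few compounds are considered here, and "the series" means these few. Any claim that something is new, unique, unknown or untested is made for them only; others in the source may bear on it.

Three compounds built on one shared core were tested in a functional assay on the whole organism (strain Swiss) with Mus musculus as the target, in the maximal electroshock model, with a stated time of 0.5 h, at a dose of 100 mg/kg by the intraperitoneal route; on this read-out lower numbers stand for a weaker effect and higher numbers for a stronger effect at the one dose given. Compound 1 `COc1cccc(N2CCN(C(=O)C(C)N3C(=O)CCC3=O)CC2)c1` gives 0% there, and compound 3 `CCC(C(=O)N1CCN(c2cccc(F)c2)CC1)N1C(=O)CCC1=O` gives 0%; these two values are level with each other and together are the lowest of the three. Compound 2 `COCC(C(=O)N1CCN(c2cccc(C(F)(F)F)c2)CC1)N1C(=O)CCC1=O` gives 75%, a number beyond the scatter above the other two. Compound 4 `CC(C(=O)N1CCN(c2ccccc2F)CC1)N1C(=O)CCC1=O` has not been measured yet; it differs from compound 1 in one place: 2-fluorophenyl in place of 3-methoxyphenyl on an amine nitrogen in a ring. Within the data shown here, no measured pair differs in only one place, so no single-change step is available for guidance. A large rise is not supported, because compound 3 also gives 0% while carrying a fluorophenyl group. The step expected here is a number 10 percentage points higher from compound 1 to compound 4 (within the scatter), small and within the scatter. Compound 4 is estimated at 10%, with a range from 0% to 40%.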

Compound 4, a percentage reported as activity, at one dose (the size of the read-out at that dose, not a potency): 0%
Estimate against measurement, compound 4: 10 percentage points above, and the stated range covers the measured number.
By their numbers in this assay, from the lowest: compounds 1, 3 and 4 (each within the scatter of the next); then compound 2.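

In this assay, among these compounds, 2-fluorophenyl in place of 3-methoxyphenyl on an amine nitrogen in a ring gives no change at the digits printed from compound 1 to compound 4 (within the scatter) and is the only single-change step available in this set. At this position, this exchange therefore leaves the read-out at the bottom of its scale, where any difference between the two compounds cannot be seen. No measurement here explains this result.

Still open, from the compounds shown here alone, is whether a chlorophenyl group or a pyridine ring at this position would raise the read-out. Going by these compounds, it is also open whether the trifluoromethyl-bearing phenyl group of compound 2 would do so on the core of compound 1.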